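Aryl swap on the ring nitrogen: compound 3 to compound 4

A few compounds are considered here, and "the series" means these few. Any claim that something is new, unique, unknown or untested is made for them only; others in the source may bear on it.

Compound 3 `CCOC(=O)c1c(-c2cc3ccccc3oc2=O)nn(-c2ccc(C)c(C)c2)c1C(=O)OCC` gives 52000 nM in a functional assay on A549 cells (Homo sapiens) for cytotoxicity, read by MTT assay, with a stated time of 48 h; a lower number here means a stronger inhibitor, a higher number a weaker inhibitor. Compound 2 `CCOC(=O)c1c(-c2cc3ccccc3oc2=O)nn(-c2cccc(C)c2)c1C(=O)OCC` gives 52000 nM, and no change at the digits printed from compound 2 to compound 3 (within the scatter); the two stand level, together the lowest of the three numbers. Compound 1 `CCOC(=O)c1c(-c2c(Cl)c3cc(C)ccc3oc2=O)nn(-c2cccc(Cl)c2)c1C(=O)OCC` gives 128000 nM, the furthest from compound 3 and beyond the scatter. Compound 4 `CCOC(=O)c1c(-c2cc3ccccc3oc2=O)nn(-c2cccc(Cl)c2)c1C(=O)OCC` carries 3-chlorophenyl in place of 3,4-dimethylphenyl on an aromatic nitrogen. Going by the values given here, the only single-point step in hand, no change at the digits printed from compound 2 to compound 3 (within the scatter), altered the same aryl ring without moving the number. Compound 1 also carries the 3-chlorophenyl group but differs from compound 3 in two further places, so its value cannot be assigned to the aryl change alone. The step of a 1.3-fold higher number from compound 3 to compound 4 (0.10 log units; within the scatter) is therefore expected to stay within the scatter. For compound 4 the estimate is 65000 nM, with a range from 30000 nM to 140000 nM.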

Compound 4, half-maximal inhibitory concentration: 28000 nM
Compound 4: middle estimate off by 2.3-fold (0.37 log units), on the high side; measured number below the stated range.
By their numbers in this assay, from the lowest: compounds 4, 2 and 3 (each within the scatter of the next); then compound 1.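

In this assay the swap on the aromatic nitrogen gives a 1.9-fold lower number from compound 3 to compound 4 (0.27 log units; within the scatter) and the single replacement of chloro for methyl on an aromatic carbon gives a 1.9-fold lower number from compound 2 to compound 4 (0.27 log units; within the scatter). Both steps stay within the scatter, so this position has now accepted chloro as well as methyl substitution on the aryl ring without a measurable shift. No measurement here explains these readings.

Going by these compounds, whether an amine or a carboxylic acid on this aryl ring would move the number beyond the scatter remains open. So does the effect of replacing either ethoxycarbonyl group with a longer chain.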